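The source may hold more compounds than are shown below. What is called first, only, known or untested is meant among the compounds shown, and "the series" means these compounds.

Measured in a functional assay on A549 cells (Homo sapiens) for cytotoxicity, read by resazurin assay, with a stated time of 72 h; a lower number here means a stronger inhibitor, a higher number a weaker inhibitor:
- compound 1 `N#Cc1cc(-c2ccccc2)n(-c2ccc(Cl)cc2)c1N`: 7700 nM
- compound 2 `Nc1c(-c2nc3ccccc3[nH]2)cc(-c2ccccc2)n1-c1ccccn1`: 8000 nM
- compound 3 `Nc1c(-c2nc3ccccc3[nH]2)cc(-c2ccccc2)n1-c1cccc(Cl)c1`: 7000 nM

All three values lie within the usual scatter of one another, so compound 3 cannot be separated from compound 1 or compound 2 on these numbers.

Compound 4 `Nc1c(-c2nc3ccccc3[nH]2)cc(-c2ccccc2)n1-c1ccc(Cl)cc1` has 4-chlorophenyl in place of 3-chlorophenyl on an aromatic nitrogen of the shared core: 4-chlorophenyl in place of 3-chlorophenyl on an aromatic nitrogen. The two compounds have the same atoms, joined differently.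

Among the compounds with values here, no measured pair tests this exact swap. The nearest evidence is a change of group on the same nitrogen, a 1.1-fold lower number from compound 2 to compound 3 (0.06 log units; within the scatter), which stays within the scatter. Compound 1 already carries 4-chlorophenyl there, though with a nitrile where compound 4 has a 1H-benzimidazol-2-yl group, and compound 1 gives 7700 nM.

No step beyond the scatter is therefore expected in this assay, and the estimated step is no change at the digits printed from compound 3 to compound 4 (within the scatter). Compound 4 is expected at about 7000 nM, with an estimated range of 3000 nM to 15000 nM.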

Compound 4, half-maximal inhibitory concentration: 9900 nM
Beside the measured number, compound 4's estimate is 1.4-fold (0.15 log units) below it; the measured number falls inside the stated range.
By their numbers in this assay, from the lowest: compounds 3, 1, 2 and 4 (each within the scatter of the next).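

Swapping 3-chlorophenyl for 4-chlorophenyl on the aromatic nitrogen, with the shared core held fixed, gives a step within the scatter in this assay (a 1.4-fold higher number from compound 3 to compound 4 (0.15 log units; within the scatter)), and so does 4-chlorophenyl in place of pyridin-2-yl (a 1.2-fold higher number from compound 2 to compound 4 (0.09 log units; within the scatter)). With 4-chlorophenyl held on that nitrogen, a second position can now be read as well: 1H-benzimidazol-2-yl in place of cyano on the aromatic carbon also stays within the scatter (a 1.3-fold higher number from compound 1 to compound 4 (0.11 log units; within the scatter)). Nothing available explains why these numbers lie so close together.

Still open, on these data alone, is whether a 4-methoxyphenyl or 4-carboxyphenyl group on the nitrogen, or an amide in place of the 1H-benzimidazol-2-yl group, would step beyond the scatter. Also open, as far as these compounds go, is what an acetamide in place of the amino group would do.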